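The compounds below may be only part of what the source reports. "The series", "measured", "known", "first", "only" and "open" are said of these compounds alone.

Measured compounds:
- Compound 1, `Cc1nc(N(C)c2ccc([Se]C#N)c(Cl)c2)c2ccccc2n1`: 11 nM
- Compound 2, `Cc1nc(N(C)c2ccc([Se]C#N)c(F)c2)c2ccccc2n1`: 8 nM

Compound 1 and compound 2 share the same core and differ only in one halogen on an aromatic carbon. In a functional assay on RKO cells (Homo sapiens) for inhibition, read by MTT assay, with a stated time of 48 h (a higher number here means a weaker inhibitor, a lower number a stronger inhibitor), compound 1 gives 11 nM, and compound 2 gives 8 nM. Compound 1 has the higher of the two numbers, but the gap, a 1.4-fold lower number from compound 1 to compound 2 (0.14 log units; within the scatter), is within the scatter, so the two compounds cannot be told apart on potency.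

Compound 3, `C[Se]c1ccc(N(C)c2nc(C)nc3ccccc23)cc1Cl`, has not yet been measured in this assay. It keeps the chloro of compound 1 and changes the group on the selenium: methyl in place of cyano on a selenium. For the measured compounds named here, no measured step touches this part of the molecule; the only step available, a 1.4-fold lower number from compound 1 to compound 2 (0.14 log units; within the scatter), swaps one halogen for another and says nothing about what happens on the selenium. The expectation for compound 3 is therefore uncertain and rests on a wide range. Compound 3 is estimated at 100 nM, between 15 nM and 800 nM. This expected step, a 9.1-fold higher number from compound 1 to compound 3 (0.96 log units; beyond the scatter), leans toward a higher number, but the range also covers no change beyond the scatter.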

Compound 3, half-maximal inhibitory concentration: 4 nM
Compound 3: middle estimate off by 25-fold (1.40 log units), on the high side; the measured number lies below the stated range.
By their numbers in this assay, from the lowest: compounds 3, 2 and 1 (each within the scatter of the next, the first and the last beyond it).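

The group on the selenium can change a great deal without losing activity in this assay: methyl in place of cyano gives a 2.8-fold lower number from compound 1 to compound 3 (0.44 log units; beyond the scatter), a modest step, but one beyond the scatter and in the direction of a stronger inhibitor. For the compounds shown here, this is the first view of this position, since the halogen swap elsewhere on the ring said nothing about it, and it shows that, for this pair at least, the cyano group with its triple bond and its hydrogen-bond acceptor is not required for a low number, as a single carbon with no acceptor serves at least as well. Nothing available here explains why the number falls with this change.

Only two groups on the selenium are shown, so it remains open whether a longer chain such as ethyl, or a group carrying an amine or a carboxylic acid, would keep the number low or raise it. Going by these compounds, it is also open whether methyl in place of cyano would give a similar step when the ring carries fluoro instead of chloro, as it does in compound 2.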